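A few compounds are considered here, and "the series" means these few. Any claim that something is new, unique, unknown or untested is made for them only; others in the source may bear on it.

Working notes on the series.

Of the compounds shown here, three have been measured in a functional assay on DU-145 cells (Homo sapiens) for inhibition, read by trypan blue exclusion, with a stated time of 96 h; on this read-out lower numbers stand for stronger inhibition of growth and higher numbers for weaker inhibition of growth. Compound 1 `COc1ccc(/C=C(/Sc2ccc(C)cc2)C(=O)c2ccc(Br)cc2)cc1` gives 50000 nM, and compound 2 `COc1ccc(/C=C(/SCc2ccc(F)cc2)C(=O)c2ccc(Br)cc2)cc1` gives 50000 nM. Compound 3 `COc1cc(OC)c(/C=C(/SCc2ccc(F)cc2)C(=O)c2ccc(Br)cc2)c(OC)c1` gives 1000 nM, the lowest of the three numbers; its step to compound 1 and its step to compound 2 are each beyond the scatter, so compound 3 is the strongest of the measured set.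

The difference between the core of compound 3 and the core of compound 2 is not broken down here. Compound 2 and compound 1 differ in one place, (4-methylphenyl in place of 4-fluorobenzyl on a sulfur), and the measured step of no change at the digits printed from compound 2 to compound 1 (within the scatter) shows that this exchange left the number where it was.

Compound 4 `COc1cc(OC)c(/C=C(/Sc2ccc(C)cc2)C(=O)c2ccc(Br)cc2)c(OC)c1` is not yet measured. It carries the same exchange relative to compound 3, (4-methylphenyl in place of 4-fluorobenzyl on a sulfur), and the two place descriptions read the same word for word, so the change is the same one, now made on the core of compound 3. For the measured compounds named here, the only measured instance of this change, from compound 2 to compound 1, gave no shift, and that single observation is the whole basis for what follows; no second pair is available to test it.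

On that basis compound 4 is expected to sit close to compound 3, at about 1500 nM, with a plausible range from 400 nM to 8000 nM, which means an expected step of a 1.5-fold higher number from compound 3 to compound 4 (0.18 log units; within the scatter) from compound 3 to compound 4.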

Compound 4, concentration for 50% growth inhibition: > 100000 nM
Compound 4 gave a limit, no number (the forecaster's own chance of this, stated with the estimate: 10%); middle value at least 66-fold (1.82 log units) away from the limit.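

The exchange of 4-fluorobenzyl for 4-methylphenyl on a sulfur does not carry over from one core to the other in this assay, and the two steps differ by more than their scatter: the same change on two cores in this assay, no change at the digits printed (within the scatter) from compound 2 to compound 1 and an at least 100-fold higher number (2.00 log units; beyond the scatter) from compound 3 to compound 4, at least 100-fold (2.00 log units) apart, beyond the scatter of two such steps

Compound 4 gives > 100000 nM, which is a limit of the assay and not a number: the limit of > 100000 nM in this assay, at which 1 of the 4 values shown sits.

The new step, an at least 100-fold higher number from compound 3 to compound 4 (2.00 log units; beyond the scatter), gives only the smallest size the shift can have, and with one pair on each core the data show that the outcome of this exchange depends on the core in these two cases, but not how it would turn out on any other core, nor why the two cores part.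

The compounds shown leave open how much of the step comes from losing the benzyl carbon and how much from replacing fluorine with methyl, a question that 4-methylbenzyl or 4-fluorophenyl on the sulfur of the core of compound 3 would separate. Also open, from the compounds shown here alone, is whether a quite different group on the sulfur, such as an amine-bearing chain or a carboxylic acid, would keep the number of compound 3 on that core.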